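Replacing the carbamate with a methylpyrimidine on the ring nitrogen

A few compounds are considered here, and "the series" means these few. Any claim that something is new, unique, unknown or untested is made for them only; others in the source may bear on it.

Compound 3 `COC(=O)N1c2ccc(C3(NC(=O)c4ccc(F)cc4)CC3)cc2[C@@H]2CC[C@@H]21` gives 5.6 nM in an assay on HeLa cells for inhibition of Indoleamine 2,3-dioxygenase 1 (Homo sapiens); a lower number here means a stronger inhibitor, a higher number a weaker inhibitor. Among the three measured compounds it has the second highest number: compound 1 `Cc1nccc(N2c3ccc(C4(NC(=O)c5ccc(F)cc5)CC4)cc3[C@H]3CC[C@H]32)n1` gives 3.8 nM, within the scatter of compound 3, while compound 2 `O=C(NC1(c2ccc3c(n2)CCN3c2ccnc(C(F)(F)F)n2)CCC1)c1ccc(Cl)cc1` gives 93 nM, a gap beyond the scatter. Compound 4 `Cc1nccc(N2c3ccc(C4(NC(=O)c5ccc(F)cc5)CC4)cc3[C@@H]3CC[C@@H]32)n1` has not yet been measured. The change from compound 3 to compound 4 is 2-methylpyrimidin-4-yl in place of methoxycarbonyl on a nitrogen on an aromatic ring in a ring. Among the measured compounds shown here, no pair of measured compounds differs by this single change, so no measured step exists for it. Compound 1 already carries the 2-methylpyrimidin-4-yl group on the shared core, and its number sits within the scatter of compound 3, so the step from compound 3 to compound 4 is expected to stay within the scatter, with no direction favoured. On that basis compound 4 is estimated at 4.5 nM in this assay, with a range from 1.5 nM to 14 nM, which would mean a step of a 1.2-fold lower number from compound 3 to compound 4 (0.09 log units; within the scatter).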

Compound 4, half-maximal inhibitory concentration: 5 nM
Beside the measured number, compound 4's estimate is 1.1-fold (0.05 log units) below it; measured number inside the range.
By their numbers in this assay, from the lowest: compounds 1, 4 and 3 (each within the scatter of the next); then compound 2.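

In this assay, 2-methylpyrimidin-4-yl in place of methoxycarbonyl on a nitrogen on an aromatic ring in a ring gives a 1.1-fold lower number from compound 3 to compound 4 (0.05 log units; within the scatter), so on the shared core this position takes either group, one with a six-membered aromatic ring and one with no ring, without a change that can be read. Inverting both stereocentres gives a 1.3-fold higher number from compound 1 to compound 4 (0.12 log units; within the scatter), so with 2-methylpyrimidin-4-yl in place, this assay does not separate the two configurations as drawn. This comparison isolates configuration alone: the fact that compounds 1 and 4 differ only in the configuration as drawn.

As far as these compounds go, it remains open whether an amine or a carboxylic acid on this nitrogen would keep the number in the same range. From the compounds shown here alone, it also remains open whether the mirror image of compound 3 would match compound 3 in the way compound 1 matches compound 4.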